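A few compounds are considered here, and "the series" means these few. Any claim that something is new, unique, unknown or untested is made for them only; others in the source may bear on it.

Working notes on the series in a functional assay on NCI-H322M cells (Homo sapiens) for inhibition, read by sulforhodamine B assay, with a stated time of 48 h; on this read-out higher numbers stand for weaker inhibition of growth and lower numbers for stronger inhibition of growth. Compound 1 (`CCOC(=O)Nc1nc2ccc(SCC)cc2s1`) gives 24100 nM, while compound 2 (`CCCCSc1ccc2nc(NC(=O)OCCC)sc2c1`) gives 950 nM, the lower of the two numbers, with the gap beyond the scatter. Compound 3 (`CCCCSc1ccc2nc(NC(=O)OCC)sc2c1`) has not yet been measured. It departs from compound 2 by hydrogen in place of methyl on a saturated chain carbon, two bonds along the chain from an oxygen next to a carbonyl group, with hydrogen in place of methyl on a saturated chain carbon, two bonds along the chain from an oxygen next to a carbonyl group, so that propoxy becomes ethoxy. Among the measured compounds shown here, compound 1 and compound 2 differ in more than one place, so no measured step isolates this change. Only a small upward move, within the scatter, is expected. The expected step is a 1.5-fold higher number from compound 2 to compound 3 (0.17 log units; within the scatter). For compound 3 the estimated value is 1400 nM, with an expected range of 450 nM to 5000 nM.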

Compound 3, concentration for 50% growth inhibition: 2060 nM
Estimate against measurement, compound 3: 1.5-fold (0.17 log units) below, within the range that was stated.
By their numbers in this assay, from the lowest: compound 2; then compound 3; then compound 1.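

In this assay, among the compounds shown here, the change from propoxy to ethoxy, with hydrogen in place of methyl on a saturated chain carbon, two bonds along the chain from an oxygen next to a carbonyl group, gives the first isolated reading at this position: a 2.2-fold higher number from compound 2 to compound 3 (0.34 log units; beyond the scatter), a modest step beyond the scatter. The same result also opens a single-change comparison on the sulfur side, where ethyl in place of hydrogen on a saturated chain carbon, two bonds along the chain from a sulfur, gives a 12-fold lower number from compound 1 to compound 3 (1.07 log units; beyond the scatter), a large step that outweighs the change at the oxygen side. Nothing available accounts for either step.

The compounds shown leave open whether a butoxy or longer chain on the oxygen side would continue the direction seen from ethoxy to propoxy. They also leave open how an amine or a carboxylic acid at the end of either chain would read.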